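The compounds below may be only part of what the source reports. "The series", "measured", "known", "first", "only" and "open" are said of these compounds alone.

Compound 1 `Cc1nc(-c2ccccc2)sc1C(=O)CSc1nc(-c2ccccc2)c(C#N)c(=O)[nH]1` is the unsubstituted parent of this set. In a functional assay on U-87MG ATCC cells for antiproliferative activity against U-87 MG (Homo sapiens), read by MTT assay, with a stated time of 48 h (on this read-out lower numbers stand for stronger inhibition and higher numbers for weaker inhibition), compound 1 gives 56600 nM, the highest number of the three measured; its nearest neighbour is compound 3 `Cc1nc(-c2ccccc2)sc1C(=O)CSc1nc(-c2ccc(Cl)cc2)c(C#N)c(=O)[nH]1` at 43400 nM, the step being a 1.3-fold lower number from compound 1 to compound 3 (0.12 log units; within the scatter), and the furthest is compound 2 `Cc1nc(-c2ccccc2)sc1C(=O)CSc1nc(-c2cccc(Cl)c2)c(C#N)c(=O)[nH]1` at 28200 nM, with a 2.0-fold lower number from compound 1 to compound 2 (0.30 log units; within the scatter). Compound 4 `COc1ccc(-c2nc(C)c(C(=O)CSc3nc(-c4ccccc4)c(C#N)c(=O)[nH]3)s2)cc1` differs from compound 1 by methoxy in place of hydrogen on an aromatic carbon. Within the data shown here, no measured step touches this part of the core; the only aromatic substitutions seen so far, chloro in place of hydrogen in compound 2 and compound 3, stayed within the scatter. A step of a 1.1-fold lower number from compound 1 to compound 4 (0.05 log units; within the scatter) is therefore expected, nothing beyond the scatter. Compound 4 is estimated at 50000 nM, within 20000 nM to 120000 nM.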

Compound 4, half-maximal inhibitory concentration: 57300 nM
Estimate against measurement, compound 4: 1.1-fold (0.06 log units) below; the measured number falls inside the stated range.
By their numbers in this assay, from the lowest: compounds 2, 3, 1 and 4 (each within the scatter of the next, the first and the last beyond it).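

Methoxy on this ring, para to a large group, is the first change in a part of the core that no earlier step touched; in this assay the step is a 1.0-fold higher number from compound 1 to compound 4 (0.01 log units; within the scatter) and stays within the scatter. So phenyl and 4-methoxyphenyl cannot be told apart here, and this single change gives no sign that the position affects the read-out. No other data bear on this result.

As far as these compounds go, whether an amine or a carboxylic acid at this place would give a step beyond the scatter remains open. So does how methoxy here would behave alongside the chloro groups of compound 2 and compound 3.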